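Compound 2 to compound 3: a new group on the shared core

The compounds below may be only part of what the source reports. "The series", "measured", "known", "first", "only" and "open" are said of these compounds alone.

In a functional assay on A549 cells (Homo sapiens) for antiproliferative activity, read by MTT assay, with a stated time of 48 h (a higher number here means a weaker inhibitor, a lower number a stronger inhibitor), compound 2 `O=C(/C=C/c1ccc(O)c(O)c1)N1CCN(c2cccc(Cl)c2)CC1` gives 1.29 ug/mL and compound 1 `O=C(/C=C/c1ccc(O)c(O)c1)N1CCN(c2ccc(F)cc2)CC1` gives 1.25 ug/mL, values within the scatter of each other. Compound 3 `COc1ccccc1N1CCN(C(=O)/C=C/c2ccc(O)c(O)c2)CC1` has 2-methoxyphenyl in place of 3-chlorophenyl on an amine nitrogen in a ring. Within the data shown here, only one measured step bears on this change, a 1.0-fold higher number from compound 1 to compound 2 (0.01 log units; within the scatter), and no measured compound carries 2-methoxyphenyl. A step within the scatter is therefore expected in this assay, with no direction favoured, and the estimated step is a 1.0-fold higher number from compound 2 to compound 3 (0.00 log units; within the scatter). Compound 3 is expected at 1.3 ug/mL, with an estimated range of 0.65 ug/mL to 2.8 ug/mL.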

Compound 3, half-maximal inhibitory concentration: 0.98 ug/mL
Compound 3: the middle estimate sits 1.3-fold (0.12 log units) above what was measured; the measured number falls inside the stated range.
By their numbers in this assay, from the lowest: compounds 3, 1 and 2 (each within the scatter of the next).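

In this assay, 2-methoxyphenyl on the amine nitrogen in a ring gives a 1.3-fold lower number from compound 2 to compound 3 (0.12 log units; within the scatter) and a 1.3-fold lower number from compound 1 to compound 3 (0.11 log units; within the scatter) as its two steps. The position thus accommodates a phenyl group bearing a hydrogen-bond acceptor, with compounds 1, 2 and 3 all within the scatter of one another. Nothing available bears on the cause of this result.

Going by these compounds, whether a non-aromatic group at this position, such as an alkyl chain or a phenyl bearing a carboxylic acid or an amine, would give a step beyond the scatter remains open. On these data alone, the effect of changes elsewhere on the shared core also remains open.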